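The source may hold more compounds than are shown below. What is called first, only, known or untested is meant among the compounds shown, and "the series" means these compounds.

Compound 1 `CCCCNC(=O)C1C(C(=O)O)[C@@H]2CC[C@H]1O2` carries a butyl amide on its bicyclic core, which also bears a free carboxylic acid. In an ADME assay on MCF7 cells (Homo sapiens) for cytotoxicity, read by MTT assay, with a stated time of 72 h (a lower number here means a stronger inhibitor of growth, a higher number a weaker inhibitor of growth), compound 1 gives 10000 nM. Compound 2 `CCOC(=O)c1cn[nH]c1NC(=O)C1C(C(=O)O)[C@@H]2CC[C@H]1O2` places a pyrazole ester amide on the same core, and in this assay compound 2 gives 10000 nM. The two values stand level at the digits shown, within the scatter of repeated measurements, so compound 1 is neither weaker nor stronger than compound 2 on these numbers; both sit at a weak level of growth inhibition.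

Compound 3 `CCCCCCCCNC(=O)C1C(C(=O)O)[C@@H]2CC[C@H]1O2` has not yet been measured in this assay. Its difference from compound 1 is butyl in place of hydrogen on a saturated chain carbon, four bonds along the chain from an amide-type nitrogen. Going by the values given here, with only two compounds measured, both at the same weak level, no step between measured compounds is available to guide the expectation. Compound 3 is therefore expected to show no change beyond the scatter, with the step of no change at the digits printed from compound 1 to compound 3 (within the scatter) from compound 1 to compound 3 anticipated as flat. Compound 3 is estimated at 10000 nM, with a range from 4000 nM to 25000 nM.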

Compound 3, concentration for 50% growth inhibition: 10000 nM
Beside the measured number, compound 3's estimate shows no gap at the digits printed; the measured number falls inside the stated range.
By their numbers in this assay, from the lowest: compounds 1, 2 and 3 (each within the scatter of the next).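

In this assay, butyl in place of hydrogen on a saturated chain carbon, four bonds along the chain from an amide-type nitrogen, gives no change at the digits printed from compound 1 to compound 3 (within the scatter). Going by these compounds alone, the earlier compounds offered no step between measured compounds, so this is the first direct reading of a single change on the shared core, and it shows that this added length of chain leaves the growth-inhibition read-out where it stood. Nothing available here accounts for this flat result.

The compounds shown leave open whether a longer chain at this position, or an amine or a hydroxyl group at the end of the chain, would move the read-out away from the level shared by compounds 1 and 3. They also leave open what a methyl ester in place of the carboxylic acid on the shared core would do, since that acid stays the same in compound 1 and compound 3.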